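The source may report more compounds than this note shows. Statements on the series, on what has been measured and on what is new or still open speak of the compounds shown alone.

In a functional assay on HCT-116 cells (Homo sapiens) for antiproliferative activity, read by MTT assay, with a stated time of 72 h (on this read-out higher numbers stand for weaker inhibition and lower numbers for stronger inhibition), compound 1 `O=C(Nc1ccc(Nc2nccc(NC3CCCCC3)n2)cc1)Nc1ccc(Cl)c(C(F)(F)F)c1`, carrying cyclohexyl on a nitrogen, gives 5950 nM and compound 2 `O=C(Nc1ccc(Nc2nccc(NC3CC3)n2)cc1)Nc1ccc(Cl)c(C(F)(F)F)c1`, carrying cyclopropyl there, gives 16400 nM on the same core. Compound 3 `O=C(Nc1ccc(Nc2nccc(Nc3cccc(Cl)c3)n2)cc1)Nc1ccc(Cl)c(C(F)(F)F)c1`, carrying 3-chlorophenyl, gives 4820 nM at the low end of these numbers. Putting that group in place measured a 1.2-fold lower number from compound 1 to compound 3 (0.09 log units; within the scatter) and a 3.4-fold lower number from compound 2 to compound 3 (0.53 log units; beyond the scatter) as the two steps. Compound 4 `Cn1cc(Nc2ccnc(Nc3ccc(NC(=O)Nc4ccc(Cl)c(C(F)(F)F)c4)cc3)n2)cn1` has 1-methyl-1H-pyrazol-4-yl in place of 3-chlorophenyl on a nitrogen on an aromatic ring being the whole difference. Within the data shown here, no measured step tests a five-membered aromatic ring, so the only guide is the size of these steps, together with a 2.8-fold higher number from compound 1 to compound 2 (0.44 log units; beyond the scatter) as the third. A modest move to higher numbers is therefore expected in this assay and nothing large. The estimated change is a 1.7-fold higher number from compound 3 to compound 4 (0.22 log units; within the scatter) in size. Compound 4 is estimated at 8000 nM with 3000 nM to 20000 nM as the expected range.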

Compound 4, half-maximal inhibitory concentration: 4850 nM
The estimate for compound 4 lay 1.6-fold (0.22 log units) above the measured number, and the stated range covers the measured number.
By their numbers in this assay, from the lowest: compounds 3, 4 and 1 (each within the scatter of the next); then compound 2.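

In this assay, a five-membered aromatic ring with 2 hetero atoms can stand on this nitrogen in place of the six-membered carbon ring, with a 1.0-fold higher number from compound 3 to compound 4 (0.00 log units; within the scatter). The same group gives a 1.2-fold lower number from compound 1 to compound 4 (0.09 log units; within the scatter) and a 3.4-fold lower number from compound 2 to compound 4 (0.53 log units; beyond the scatter), so among the four groups tried here, only cyclopropyl stands apart. No measurement is available to explain these results. The compounds shown leave open whether a group carrying an amine, such as 2-(dimethylamino)ethyl, or a carboxylic acid would keep the number in this range at this position.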